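The source may hold more compounds than are shown below. What is called first, only, known or untested is meant among the compounds shown, and "the series" means these compounds.

In an ADME assay on L02 cells (Homo sapiens) for cytotoxicity, read by MTT assay, with a stated time of 24 h (on this read-out lower numbers stand for stronger inhibition and higher numbers for weaker inhibition), compound 1, `O=C1/C(=C/c2ccccc2F)CN(S(=O)(=O)c2ccc(F)cc2)C/C1=C\c1ccccc1F`, gives 19100 nM, and compound 2, `CC(=O)Nc1ccc(S(=O)(=O)N2C/C(=C\c3ccc(C#N)cc3)C(=O)/C(=C/c3ccc(C#N)cc3)C2)cc1`, gives 14000 nM. For the measured compounds named here, these two numbers lie within the usual scatter of each other, so compound 1 stands level with the only other measured compound. Compound 3, `COc1cc(/C=C2\CN(S(=O)(=O)c3ccc(F)cc3)C/C(=C\c3ccccc3F)C2=O)cc(OC)c1`, is compound 1 with a single change: 3,5-dimethoxyphenyl in place of 2-fluorophenyl on a double-bonded chain carbon bound to a double-bonded ring carbon. In words, it carries 3,5-dimethoxyphenyl in place of 2-fluorophenyl on a double-bonded chain carbon bound to a double-bonded ring carbon. Although its groups differ from those of compound 1, compound 2 still gives 14000 nM, so this one swap is not expected to move the number far. The expected step is a 1.3-fold lower number from compound 1 to compound 3 (0.10 log units; within the scatter), which is no larger than the scatter, so no real direction is expected in this assay. For compound 3 the estimated value is 15000 nM, with an expected range of 6000 nM to 35000 nM.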

Compound 3, half-maximal inhibitory concentration: 18500 nM
Estimate against measurement, compound 3: 1.2-fold (0.09 log units) below, within the range that was stated.
By their numbers in this assay, from the lowest: compounds 2, 3 and 1 (each within the scatter of the next).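

This is the first pair shown that differs in one place only, so the effect of a single swap can now be read directly. In this assay, putting 3,5-dimethoxyphenyl in place of 2-fluorophenyl on a double-bonded chain carbon bound to a double-bonded ring carbon gives a 1.0-fold lower number from compound 1 to compound 3 (0.01 log units; within the scatter), so the two compounds stand level even though the entering group has more heavy atoms and brings two hydrogen-bond acceptors where the leaving group has none. No evidence at hand explains this result.

From the compounds shown here alone, whether this position would tolerate an amine or a carboxylic acid equally well remains open, since both aromatic groups compared here keep a six-membered carbon ring. Going by these compounds, it is also open whether a longer chain in this place would leave the number level.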